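The compounds below may be only part of what the source reports. "The series", "measured", "known", "first", "only" and "open" are said of these compounds alone.

Of the compounds shown here, three have been measured, and a fourth is still waiting. Compound 1 `Cc1ccc(-n2cc(C(=O)Nc3cc(F)cc(F)c3)c(=O)c3ccc(N(C)C)nc32)cc1OCCCCCCC[N+]1(C)CCCC1` and compound 2 `CN(C)c1ccc2c(=O)c(C(=O)Nc3cc(F)cc(F)c3)cn(-c3ccc(Cl)c(OCCCCCCC[N+]4(C)CCCC4)c3)c2n1` share one core, and compound 3 `Cc1cc(-n2cc(C(=O)Nc3cc(F)cc(F)c3)c(=O)c3ccc(N(C)C)nc32)ccc1OCCCCCCC[n+]1ccccc1` carries a different one; how the core of compound 3 differs from that of compound 1 is not broken down here. In an assay on LX2 cells for inhibition of COL1A1 promoter (Homo sapiens), read by a luciferase reporter, with a stated time of 24 h, tested at 50 uM (a higher number here means a stronger effect of the compound at the concentration tested, a lower number a weaker effect), compound 1 gives 55.9%. In this assay compound 2 gives 76.1%. In this assay compound 3 gives 55%. The numbers of compound 3 and compound 1 lie within the usual scatter of each other.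

Among the measured compounds shown here, the one change from compound 1 to compound 2 is chloro in place of methyl on an aromatic carbon and it produced a number 20.2 percentage points higher from compound 1 to compound 2 (beyond the scatter). Compound 4 `CN(C)c1ccc2c(=O)c(C(=O)Nc3cc(F)cc(F)c3)cn(-c3ccc(OCCCCCCC[n+]4ccccc4)c(Cl)c3)c2n1` has not been measured yet; it differs from compound 3 by chloro in place of methyl on an aromatic carbon. This is the same kind of change, not the same: in compound 2 the chloro sits ortho to a large group and para to a large group, while in compound 4 it sits ortho to a large group and meta to a large group.

Because a number 20.2 percentage points higher from compound 1 to compound 2 (beyond the scatter) was seen only once, and because the surroundings of the exchanged group are not identical, a somewhat smaller rise is expected, estimated as a number 12 percentage points higher from compound 3 to compound 4 (beyond the scatter). For compound 4 the expected number in this assay is 67%, most likely between 52% and 80%.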

Compound 4, a percentage reported as inhibition, at one concentration (the size of the read-out at that concentration, not a potency): 21.4%
For compound 4 the middle estimate is 45.6 percentage points above the measured one; measured number outside the range, below it.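

Chloro in place of methyl on an aromatic carbon does not carry a fixed effect from one core to the other in this assay, where on the core of compound 3 it gave a number 33.6 percentage points lower from compound 3 to compound 4 (beyond the scatter), whereas on the shared core of compound 1 and compound 2 it gave a number 20.2 percentage points higher from compound 1 to compound 2 (beyond the scatter). The direction of the step reverses, and the gap between the two steps is larger than scatter alone would explain: the same change on two cores in this assay, a number 20.2 percentage points higher (beyond the scatter) from compound 1 to compound 2 and a number 33.6 percentage points lower (beyond the scatter) from compound 3 to compound 4, 53.8 percentage points apart, beyond the scatter of two such steps. This shows that a gain seen for the change on one core cannot be assumed on the other, but it does not show what causes the reversal, since the two pairs differ both in their core and in the surroundings of the exchanged group, and two pairs cannot separate those differences.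

The compounds shown leave open whether another group on this aromatic carbon, such as fluoro, bromo or methoxy, would also behave differently on the two cores. They also leave open whether a shorter chain in place of the seven-carbon chain would narrow the gap, and, with only one tested concentration, whether the stronger and weaker effects seen at that concentration would hold at any other.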